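A few compounds are considered here, and "the series" means these few. Any claim that something is new, unique, unknown or untested is made for them only; others in the source may bear on it.

The following values come from a functional assay on HT-29 cells (Homo sapiens) for cytotoxicity, read by MTT assay, with a stated time of 6 days (on this read-out lower numbers stand for an effect already at smaller amounts and higher numbers for an effect only at larger amounts of compound), for three compounds:

- Compound 1 `O=c1cc(-c2ccc([N+](=O)[O-])cc2)oc2ccc(O)cc12` gives > 25 ug/mL
- Compound 2 `O=c1cc(-c2ccc([N+](=O)[O-])cc2)oc2cc(O)ccc12` gives 6.95 ug/mL
- Compound 3 `O=c1cc(-c2ccc([N+](=O)[O-])cc2)oc2c(O)c(O)ccc12` gives 3.46 ug/mL

Compound 1 reports > 25 ug/mL which is a limit and not a number. That leaves two numbers to compare. Within the data shown here, compound 2 has 6.95 ug/mL as its value in this assay and shares its place on the scale with its only numerical neighbour, the gap being a 2.0-fold lower number from compound 2 to compound 3 (0.30 log units; within the scatter) and so no real separation.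

Compound 4 (`Nc1ccc(-c2cc(=O)c3ccc(O)cc3o2)cc1`) has not yet been measured. Against compound 2 its change is amino in place of nitro on an aromatic carbon and the rest of the structure stays the same, so this is amino in place of nitro on an aromatic carbon. The one measured step, described above, is hydroxy in place of hydrogen on an aromatic carbon. Among the measured compounds shown here, that is a different change, and no measured step replaces nitro with amino. With no size or direction to carry over, no shift beyond the scatter is expected in this assay and the range is kept wide. The expected step is a 1.0-fold higher number from compound 2 to compound 4 (0.00 log units; within the scatter) on this reasoning. The estimate for compound 4 is 7 ug/mL with an expected range from 2 ug/mL to 25 ug/mL in this measurement.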

Compound 4, concentration for half-maximal effect: 4.71 ug/mL
The estimate for compound 4 lay 1.5-fold (0.17 log units) above the measured number; measured number inside the range.
By their numbers in this assay, from the lowest: compounds 3, 4 and 2 (each within the scatter of the next). At a limit, above all of these: compound 1.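

Until compound 4, every compound shown carried the nitro group, so nothing yet showed whether a number in this range depended on it. In this assay, amino in place of nitro, on an aromatic carbon para to a large group, gives a 1.5-fold lower number from compound 2 to compound 4 (0.17 log units; within the scatter), so at this position the nitro group can be exchanged for amino without a shift that can be told from the scatter, although the two groups differ in size and in hydrogen-bond donors. Compound 1 remains the only compound at a limit, which is not a number, and compound 4 does not join it: the limit of > 25 ug/mL in this assay, at which 1 of the 4 values shown sits.

On these data alone, it remains open whether other groups at this place, such as a carboxylic acid, a methoxy group or a longer chain, would stay in the same range or move beyond the scatter. It is also open whether amino in place of nitro would give the same picture on the cores of compound 1 and compound 3, as the one exchange shown stands on compound 2 alone.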